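The compounds below may be only part of what the source reports. "The series", "measured", "known", "first", "only" and "open" are said of these compounds alone.

Of the compounds shown here, three built on the same core have been measured, and the question is what a fourth will do. Compound 1 `CCC(=O)N[C@@H]1CCCc2c1cncc2N1CCc2cc(Cl)ccc2C1=O` gives 119 nM in an assay on cells for inhibition of cytochrome P450 11B2, mitochondrial (Homo sapiens), read by HTRF; on this read-out lower numbers stand for stronger inhibition and higher numbers for weaker inhibition. Compound 2 `CCS(=O)(=O)NCc1cncc(N2C(=O)c3ccc(Cl)cc3C2(C)C)c1` gives 92 nM in this assay. Compound 3 `Cc1cccnc1C(=O)NCc1cncc(N2C(=O)c3ccc(Cl)cc3C2(C)C)c1` gives 9 nM in this assay. Going by the values given here, of these three numbers compound 2 stands second highest; compound 1 lies within the usual scatter of it, and only compound 3 is set clearly apart, through the one step that goes beyond the scatter: a 10-fold lower number from compound 2 to compound 3 (1.01 log units; beyond the scatter).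

Compound 4 `CC(=O)N1CC[C@@H](Oc2cncc(N3C(=O)c4ccc(Cl)cc4C3(C)C)c2)C1` has not yet been measured. It differs from compound 2 as follows: a group of 9 heavy atoms (6 carbon, 1 nitrogen, 2 oxygen; one five-membered non-aromatic ring with 1 hetero atom) in place of a group of 7 heavy atoms (3 carbon, 1 nitrogen, 2 oxygen, 1 sulfur; no ring), on an aromatic carbon.

Among the compounds with values here, the only measured step touching this part of the molecule is the one from compound 2 to compound 3, which replaced one group on the amine nitrogen and gave a large gain. The change to compound 4 is of another kind: the whole group leaves, the hydrogen-bond donor is lost, and a five-membered ring enters. Within the data shown here, no measured pair shows what such a swap does, so the large gain seen for compound 3 cannot simply be carried over. The expected step is therefore small, near the scatter: a 1.2-fold higher number from compound 2 to compound 4 (0.08 log units; within the scatter). Compound 4 is estimated at 110 nM, between 35 nM and 350 nM.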

Compound 4, half-maximal inhibitory concentration: 11 nM
For compound 4 the middle estimate is 10-fold (1.00 log units) above the measured one, and the stated range ends above it.
By their numbers in this assay, from the lowest: compounds 3 and 4 (each within the scatter of the next); then compounds 2 and 1 (each within the scatter of the next).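

In this assay, replacing the ((ethylsulfonyl)amino)methyl group on this aromatic carbon gives an 8.4-fold lower number from compound 2 to compound 4 (0.92 log units; beyond the scatter), so the low number seen earlier is not tied to the substituted amine nitrogen that compound 2 and compound 3 share. Compound 4 has no hydrogen-bond donor in the entering group and carries a five-membered non-aromatic ring instead, yet its number lies within the scatter of that of compound 3, which shows that quite different groups at this position can reach the same low range. Nothing available here explains why either change lowers the number.

The compounds shown leave open how much each part of the entering group contributes, including its carbonyl, its ring and its one defined stereocentre, since the opposite arrangement at that centre does not appear among them. They also leave open whether a simple amine, a carboxylic acid or a longer chain on this same aromatic carbon would keep the number as low.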